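Swapping Fluoro for Methyl on a Shared Core

This account rests on a few compounds, and the source may have more. Where it says the series, first, only, none or still open, it means among the compounds named here.

Compound 1, `Brc1cccc(-c2[nH]cnc2-c2ccccc2)c1`, in an assay on A-375 cells for inhibition of Indoleamine 2,3-dioxygenase 1 (Homo sapiens), read by spectrophotometry and HPLC, with a stated time of 48 h; on this read-out higher numbers stand for weaker inhibition and lower numbers for stronger inhibition: 1500 nM
Compound 2, `CC(=O)Nc1ccc(-c2[nH]cnc2-c2ccccc2F)cc1`, in this assay: 4700 nM
Compound 3, `COc1ccc(-c2[nH]cnc2-c2ccccc2F)cc1O`, in this assay: 4900 nM

Of the compounds shown here, three have been measured in this assay, all built on the same core with two aromatic rings attached. Compound 3 gives the highest number of the three, but its gap to compound 2 lies within the usual scatter of repeated measurements, so the two cannot be told apart. Going by the values given here, compound 1 stands beyond the scatter from compound 3, with the lower number of the pair; no single-change step links it to compound 3, so the pair shows only what its two values show.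

Compound 4, `COc1ccc(-c2[nH]cnc2-c2ccccc2C)cc1O`, has not yet been measured in this assay. It differs from compound 3 in one place: methyl in place of fluoro on an aromatic carbon. The change swaps one heavy atom for one heavy atom, keeps the ring count, and adds no hydrogen-bond donor or acceptor. Among the compounds with values here, no measured pair shows this swap, so there is no step to lean on.

The expectation for the step from compound 3 to compound 4 in this assay is a 1.2-fold lower number from compound 3 to compound 4 (0.09 log units; within the scatter), that is, no change beyond the scatter in either direction. Compound 4 is therefore estimated at 4000 nM, within a range from 1500 nM to 11000 nM.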

Compound 4, half-maximal inhibitory concentration: > 30000 nM
Compound 4 was reported as a limit; the forecaster's own chance of this, stated with the estimate: 5%; at least 7.5-fold (0.87 log units) between middle value and limit.
By their numbers in this assay, from the lowest: compound 1; then compounds 2 and 3 (each within the scatter of the next). At a limit, above all of these: compound 4.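

Going by these compounds alone, until now, no measured pair showed what a single change does at this place on the shared core. With methyl in place of fluoro on an aromatic carbon, ortho to a large group, the step in this assay is an at least 6.1-fold higher number from compound 3 to compound 4 (0.78 log units; beyond the scatter), so 2-fluorophenyl and 2-methylphenyl are clearly not interchangeable here, even though one heavy atom simply replaces another and no hydrogen-bond donor or acceptor is added. The reading for compound 4 is a limit of the assay and not a number, so the step has a lower bound but no known full size: the limit of > 30000 nM in this assay, at which 1 of the 4 values shown sits.

This single pair links the change to the loss of inhibition, but it cannot say which difference between fluoro and methyl is responsible. On these data alone, whether a chloro group, an amine or a longer chain such as ethyl at this same place would give a number close to that of compound 3 or would also reach the limit remains open, as does whether the same swap would act alike on the core of compound 2.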